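A few compounds are considered here, and "the series" means these few. Any claim that something is new, unique, unknown or untested is made for them only; others in the source may bear on it.

Measured compounds:
- compound 1 `Cc1ccc2c(O)cc(-c3cccc(Cl)c3)nc2n1`: < 10 nM
- compound 2 `Oc1cc(-c2ccc3ccccc3c2)nc2ncccc12`: 1780 nM
- compound 3 `Cc1cc(C)c2c(O)cc(-c3cccc(Cl)c3)nc2n1`: 13.2 nM

The three compounds were tested in a functional assay on MDA-MB-435 cells (Homo sapiens) for antiproliferative activity; a higher number here means a weaker inhibitor of growth, a lower number a stronger inhibitor of growth. Compound 1 gives < 10 nM, which is a limit of the assay rather than a number; it is the case described by the limit of < 10 nM in this assay, at which 1 of the 3 values shown sits. Compound 3 gives 13.2 nM. Compound 2 gives 1780 nM, the highest of the two numbers, and it stands far from compound 3.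

Compound 3 comes from compound 1 by methyl in place of hydrogen on an aromatic carbon. This gave an at least 1.3-fold higher number from compound 1 to compound 3 (0.12 log units; that floor lies within the scatter).

How the core of compound 2 differs from the core of compound 1 is not broken down here.

Compound 4 `Cc1cnc2nc(-c3ccc4ccccc4c3)cc(O)c2c1` has not yet been measured. It comes from compound 2 by methyl in place of hydrogen on an aromatic carbon. Going by the values given here, this is the same kind of change as the one from compound 1 to compound 3, but not the same: in compound 3 the methyl sits ortho to a fused ring, meta to a fused ring, meta to a methyl group and opposite the ring nitrogen, whereas in compound 4 it sits two atoms from the ring nitrogen, meta to a fused ring and para to a fused ring.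

For compound 4 in this assay a small step is expected, a 1.2-fold higher number from compound 2 to compound 4 (0.09 log units; within the scatter), resting on compound 2 at 1780 nM and on the modest change seen in an at least 1.3-fold higher number from compound 1 to compound 3 (0.12 log units; that floor lies within the scatter). Compound 4 is therefore estimated at 2200 nM, between 900 nM and 5500 nM.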

Compound 4, concentration for 50% growth inhibition: 105 nM
The estimate for compound 4 lay 21-fold (1.32 log units) above the measured number; measured number outside the range, below it.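

In this assay, methyl in place of hydrogen on an aromatic carbon, two atoms from the ring nitrogen, meta to a fused ring and para to a fused ring, gave a 17-fold lower number from compound 2 to compound 4 (1.23 log units; beyond the scatter). The change therefore did not carry from one core to the other with a similar result, and the two steps stand clearly apart: the same change on two cores in this assay, an at least 1.3-fold higher number (0.12 log units; that floor lies within the scatter) from compound 1 to compound 3 and a 17-fold lower number (1.23 log units; beyond the scatter) from compound 2 to compound 4, at least 22-fold (1.34 log units) apart, beyond the scatter of two such steps Compound 1 gives < 10 nM, a limit of the assay and not a number, and the two pairs differ both in the core and in where the methyl sits, so the data do not show how large the earlier step truly is or which of these differences separates the two results.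

The compounds shown leave open whether methyl at the place it occupies in compound 4 would lower the number on the core of compound 1, and whether methyl at the place it occupies in compound 3 would raise or lower it on the core of compound 2. They also leave open whether an ethyl group, a methoxy group or an amine at the place of the methyl in compound 4 would keep the lower number seen there.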